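The source may report more compounds than this note shows. Statements on the series, on what has been measured and on what is new or still open speak of the compounds shown alone.

Measured compounds:

Compound 1 `CS(=O)(=O)c1ccc(F)cc1NCC1=NCCN1`: 91%
Compound 2 `CS(=O)(=O)c1cc(F)ccc1NCC1=NCCN1`: 32%
Compound 3 `CSc1ccc(F)cc1NCC1=NCCN1`: 97%

All values come from a functional assay on CHO cells for agonist activity at Alpha-2C adrenergic receptor (Homo sapiens); on this read-out higher numbers stand for larger maximal responses and lower numbers for smaller maximal responses. Compound 1 and compound 2 are built from the same atoms joined differently; the difference between the two cores is not broken down here. Compound 2 gives the lowest of the three numbers, and its gaps to compound 1 and compound 3 lie beyond the scatter. The change methylsulfanyl in place of methylsulfonyl on an aromatic carbon produced a number 6 percentage points higher from compound 1 to compound 3 (within the scatter).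

Compound 4 `CSc1cc(F)ccc1NCC1=NCCN1` is not yet measured. It differs from compound 2 by methylsulfanyl in place of methylsulfonyl on an aromatic carbon, the same kind of change as that from compound 1 to compound 3, the place differing in being meta rather than para to the fluoro group. Resting on the earlier step of a number 6 percentage points higher from compound 1 to compound 3 (within the scatter), the expected step is a number 6 percentage points higher from compound 2 to compound 4 (within the scatter). Compound 4 is therefore estimated at 38%, with a likely range from 18% to 65%.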

Compound 4, largest response reached (reported as maximum), in percent of the reference or control that the assay uses: 82%
Compound 4: the middle estimate sits 44 percentage points below what was measured; measured number outside the range, above it.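

Methylsulfanyl in place of methylsulfonyl on an aromatic carbon gives, in this assay, a number 50 percentage points higher from compound 2 to compound 4 (beyond the scatter). The size of this step does not carry over from one core to the other: the same change on two cores in this assay, a number 6 percentage points higher (within the scatter) from compound 1 to compound 3 and a number 50 percentage points higher (beyond the scatter) from compound 2 to compound 4, 44 percentage points apart, beyond the scatter of two such steps

Within the data shown here, two pairs show only that a step read on one core cannot be assumed for the other; they do not show what sets the two steps apart, or how the change would behave on a further core.

Open, as far as these compounds go, is how other groups in the same place would read on either core, such as an amine or a carboxylic acid. Also open, from the compounds shown here alone, is whether a longer chain on the sulfur, such as ethylsulfanyl, would follow methylsulfanyl.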